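The source may hold more compounds than are shown below. What is called first, only, known or untested is meant among the compounds shown, and "the series" means these compounds.

Compound 1 `COc1cc(O)c(C)c2c1CC[C@H](c1ccc(O)cc1)O2`: 74000 nM
Compound 2 `COc1cc2cc(Cc3ccc(O)cc3)c(=O)oc2cc1O`: 69500 nM
Compound 3 `COc1cc2c(cc1O)C[C@@H](Cc1ccc(O)cc1)CO2`: 37800 nM

These three compounds were examined in a functional assay on HeLa cells (Homo sapiens) for cytotoxicity, read by MTT assay, with a stated time of 72 h; on this read-out higher numbers stand for weaker inhibition and lower numbers for stronger inhibition. The number for compound 1 lies within the scatter of the numbers for both compound 2 and compound 3, so the data set no one of these three apart. Among the measured compounds shown here, no two of them differ in a single place, which leaves no measured step to serve as a guide.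

Compound 4 `Cc1c(O)ccc2c1O[C@@H](c1ccc(O)cc1)CC2` is related to compound 1 by one change: hydrogen in place of methoxy on an aromatic carbon, meta to a hydroxy group and para to a methyl group (hydrogen in place of methoxy on an aromatic carbon). The data do not show what this change does in this assay. For the measured compounds named here, the only anchor is compound 1 at 74000 nM, and no step beyond the scatter is expected, in either direction. The estimated step is a 1.1-fold lower number from compound 1 to compound 4 (0.06 log units; within the scatter). For compound 4 the expected value is 65000 nM, with an estimated range from 28000 nM to 150000 nM.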

Compound 4, half-maximal inhibitory concentration: 89200 nM
For compound 4 the middle estimate is 1.4-fold (0.14 log units) below the measured one; low and high end bracket the measured number.
By their numbers in this assay, from the lowest: compounds 3, 2, 1 and 4 (each within the scatter of the next, the first and the last beyond it).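

In this assay the exchange of methoxy for hydrogen on this aromatic carbon, meta to a hydroxy group and para to a methyl group, gives a 1.2-fold higher number from compound 1 to compound 4 (0.08 log units; within the scatter) and so stays within the scatter. Among the compounds shown here, this is the first measured step between compounds that differ in one place, and it shows that the core of compound 1 can lose the methoxy group at this carbon without a measurable shift in the read-out. Nothing at hand explains this outcome.

The compounds shown carry only methoxy or hydrogen at this carbon, so it remains open whether an amine, a carboxylic acid or a longer chain such as butoxy there would shift the number beyond the scatter. From the compounds shown here alone, it also remains open whether the same exchange would give a similar step on a different core.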